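Amino for Chloro on the Shared Core of Compound 1

The compounds below may be only part of what the source reports. "The series", "measured", "known", "first", "only" and "open" are said of these compounds alone.

Compound 1 `ClCc1ccccc1Cn1cnc2c(Cl)nc(Cl)nc21` has no result in a functional assay on SNB-19 cells (Homo sapiens) for cytotoxicity, read by sulforhodamine B assay, with a stated time of 48 h; a lower number here means that less compound is tolerated, a higher number that more compound is tolerated; its value there is "not determined" (no result reported), so it stands without a number. Two related compounds give a sense of the range: compound 2 `ClCc1cccc(Cn2cnc3c(Cl)nc(Cl)nc32)c1` gives 8920 nM in this assay, and compound 3 `ClCc1cccc(Cn2cnc3nc(Cl)nc(Cl)c32)c1` gives 5120 nM in this assay. Compound 4 `Nc1nc(Cl)c2ncn(Cc3ccccc3CCl)c2n1` is obtained from compound 1 by the change (amino in place of chloro on an aromatic carbon), amino in place of chloro on an aromatic carbon, between two ring nitrogen atoms and meta to a chloro group. For the measured compounds named here, with no measured step of this kind to lean on, a modest shift toward a higher number in this assay, of a size near the edge of the scatter, is expected. Compound 4 is therefore estimated at 15000 nM, within a range from 4000 nM to 60000 nM.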

Compound 4, concentration lethal to 50% of the cells: > 100000 nM
Compound 4: only a limit was reported (the forecaster's own chance of this, stated with the estimate: 25%); middle value at least 6.6-fold (0.82 log units) away from the limit.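

In this assay compound 4 gives > 100000 nM, which is a limit and not a number. For the compounds shown here, compound 1 has no result there, so no step between compound 1 and compound 4 can be read. The compounds shown leave open how far amino in place of chloro moves the value in this assay.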